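A few compounds are considered here, and "the series" means these few. Any claim that something is new, unique, unknown or untested is made for them only; others in the source may bear on it.

Compound 1 `N#Cc1ccccc1CN1CCc2c(sc(NC(=O)c3ccccc3Cl)c2C(N)=O)C1` was tested in a functional assay on HeLa cells (Homo sapiens) for antiproliferative activity, with a stated time of 24 h; on this read-out lower numbers stand for stronger inhibition and higher numbers for weaker inhibition. Compound 1 gives > 50000 nM, which is a limit of the assay and not a measured number. Among the two values at hand, compound 1 therefore stands at the weak end, as noted in the limit of > 50000 nM in this assay, at which 1 of the 2 values shown sits. Compound 2 `NC(=O)c1c(NC(=O)c2ccccc2F)sc2c1CCN(Cc1cccc(Cl)c1)C2` shares the core with compound 1 and carries a 3-chlorobenzyl group on the ring amine nitrogen together with a fluorine in place of the chlorine on the amide; in this assay compound 2 gives 49500 nM.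

Compound 3 `NC(=O)c1c(NC(=O)c2ccccc2Cl)sc2c1CCN(C(=S)Nc1ccccc1Br)C2` is not yet measured. It differs from compound 1 in one place: the 2-cyanobenzyl group on the amine nitrogen in the ring leaves, and a group carrying a sulfur, a bromine and a hydrogen-bond donor enters (a group of 10 heavy atoms (7 carbon, 1 nitrogen, 1 sulfur, 1 bromine; one six-membered aromatic ring of carbon only) in place of a group of 9 heavy atoms (8 carbon, 1 nitrogen; one six-membered aromatic ring of carbon only), on an amine nitrogen in a ring).

Among the compounds with values here, no step between measured compounds exists here, so no measured change of the same kind can guide the expectation. Both values seen sit at or near the upper end of the range, and the step from compound 1 to compound 3 is expected to be small, an at least 1.2-fold lower number from compound 1 to compound 3 (0.09 log units; that floor lies within the scatter), with a fair chance that only a limit is reported again. Compound 3 is therefore estimated at 40000 nM, between 12000 nM and 100000 nM.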

Compound 3, half-maximal inhibitory concentration: 24600 nM
Compound 3: middle estimate off by 1.6-fold (0.21 log units), on the high side; low and high end bracket the measured number.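

Within the data shown here, on the amine nitrogen in the ring, this is the first change that can be read between two compounds: the 2-cyanobenzyl group gives way to a group holding a sulfur, a bromine and a hydrogen-bond donor, and in this assay this gives an at least 2.0-fold lower number from compound 1 to compound 3 (0.30 log units; that floor lies within the scatter). Compound 3 gives a measured number, 24600 nM, so this position can carry something other than a benzyl group. The true size of the step cannot be stated, and only its floor can be read, because compound 1 carries a limit and not a number: the limit of > 50000 nM in this assay, at which 1 of the 3 values shown sits.

The sulfur, the bromine and the hydrogen-bond donor all enter together, so the compounds shown cannot tell which of them, if any, goes with the lower number. Going by these compounds, how the read-out would respond to an oxygen in place of the sulfur, to a chlorine in place of the bromine, or to a plain phenyl ring with no halogen on it remains open.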